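The compounds below may be only part of what the source reports. "The series", "measured", "known", "first", "only" and "open" are said of these compounds alone.

Measured compounds in an ADME assay on HepG2 2.2.15 cells (Homo sapiens) for cytotoxicity; on this read-out higher numbers stand for lower toxicity in this test and lower numbers for higher toxicity in this test:
Compound 1, `COCCc1ccc(OC(c2ccc(Cl)cc2)c2cnc(NC(=O)OC(C)(C)C)s2)cc1`: in this assay compound 1 gives > 50000 nM, a limit of the assay.
Compound 2, `Cc1cc(Br)cc(OC(c2ccc(Cl)cc2)c2cnc(NC(=O)OC(C)(C)C)s2)c1`: in this assay compound 2 gives > 50000 nM, again a limit.
Compound 3, `CCOC(=O)CCCNc1ncc(C(Oc2ccc3cc(Br)ccc3c2)c2ccc(Cl)cc2)s1`: in this assay compound 3 is reported as "not toxic" (no number reported), without a number.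

Compound 3 therefore stands with the other two at the non-toxic end of the values shown, none of which is a number: two sit at the limit of > 50000 nM in this assay, at which 2 of the 3 values shown sit, and the third is a verbal report. Going by the values given here, the only measured step, a step that the two limits leave unreadable from compound 1 to compound 2, is unreadable between its two limits and concerns the aryl ether, not the position changed here. Compound 4, `N#Cc1cccc(C(=O)Nc2ncc(C(Oc3ccc4cc(Br)ccc4c3)c3ccc(Cl)cc3)s2)c1`, differs from compound 3 by (3-cyanophenyl)carbonyl in place of 3-(ethoxycarbonyl)propyl on a nitrogen on an aromatic ring. Among the compounds with values here, no measured step bears on this change, so no shift beyond the scatter is expected, and compound 4 is expected to sit again near the limit in this assay, estimated at 50000 nM, range 20000 nM to 100000 nM.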

Compound 4, half-maximal cytotoxic concentration: > 50000 nM
Compound 4 gave a limit, no number; the forecaster's own chance of this, stated with the estimate: 80%; the middle value sits exactly at the limit.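

No new step can be read from compound 3 to compound 4, as compound 3 has only a verbal report and compound 4 only a limit. The compounds shown leave open at what concentration toxicity would appear in this assay: the limit of > 50000 nM in this assay, at which 3 of the 4 values shown sit.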